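This account rests on a few compounds, and the source may have more. Where it says the series, first, only, none or still open, it means among the compounds named here.

Two thioureas built on a shared core have been measured in a functional assay on HepG2 cells (Homo sapiens) for antiproliferative activity, read by MTT assay; a lower number here means a stronger inhibitor, a higher number a weaker inhibitor. Compound 1 `CNC(=O)c1ccc(Oc2cccc(NC(=S)Nc3cc(C(F)(F)F)cc(C(F)(F)F)c3)c2)nc1` gives 4550 nM in this assay. Compound 2 `CNC(=O)c1ccc(Oc2cccc(NC(=S)Nc3ccc(Cl)cc3Cl)c2)nc1` gives 21600 nM in this assay, the highest number of the two and clearly apart from compound 1, as the gap between them lies beyond the scatter. Going by the values given here, no step between measured compounds involves a single change, so the effect of the aryl group on the thiourea nitrogen can only be judged from these two numbers.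

Compound 3 `CNC(=O)c1ccc(Oc2cccc(NC(=S)Nc3ccc(OC)cc3)c2)nc1` has not yet been measured. It differs from compound 2 in one place: 4-methoxyphenyl in place of 2,4-dichlorophenyl on an amide-type nitrogen.

Among the compounds with values here, with no matching precedent among the measured compounds, the step of a 1.4-fold higher number from compound 2 to compound 3 (0.14 log units; within the scatter) is expected to be small, if anything toward a higher number. Compound 3 is therefore estimated at 30000 nM in this assay, within a range of 8000 nM to 100000 nM.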

Compound 3, half-maximal inhibitory concentration: 85300 nM
For compound 3 the middle estimate is 2.8-fold (0.45 log units) below the measured one, within the range that was stated.
By their numbers in this assay, from the lowest: compound 1; then compound 2; then compound 3.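

In this assay, the step to 4-methoxyphenyl in place of 2,4-dichlorophenyl on the amide-type nitrogen gives a 3.9-fold higher number from compound 2 to compound 3 (0.60 log units; beyond the scatter), which shows that this position responds to a change of this one group while the rest of the molecule stays the same. The change removes both chlorine atoms and adds a methoxy group in a single move, so this step cannot assign the loss to either part. Nothing available explains the size or direction of the step.

The compounds shown leave open how much of the step belongs to the chlorine atoms and how much to the methoxy group, a question that an unsubstituted phenyl group on this nitrogen would address. They also leave open how a urea would read in place of the thiourea.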